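A few compounds are considered here, and "the series" means these few. Any claim that something is new, unique, unknown or untested is made for them only; others in the source may bear on it.

Compound 1 `COc1cccc(-c2cc(=O)c3cc(NC(C)=O)ccc3o2)c1`: 10000 nM
Compound 2 `COc1c(-c2ccccc2)oc2ccc(NC(C)=O)cc2c1=O`: > 125000 nM

Both compounds were tested in an ADME assay on THP-1 cells (Homo sapiens) for cytotoxicity, read by flow cytometry and propidium iodide staining, with a stated time of 72 h; a higher number here means a weaker inhibitor, a lower number a stronger inhibitor. Compound 2 gives > 125000 nM, which is a limit of the assay and not a number. It therefore marks a starting point without an exact position on the scale.

Compound 3 `COc1cccc(-c2oc3ccc(NC(C)=O)cc3c(=O)c2OC)c1` is reached from compound 2 by a single change: methoxy in place of hydrogen on an aromatic carbon. This places methoxy in place of hydrogen on an aromatic carbon, turning phenyl into 3-methoxyphenyl. Among the measured compounds shown here, no measured pair shows this change on its own, so any expectation rests on indirect evidence.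

Compound 3 shares the 3-methoxyphenyl group with compound 1, which gives 10000 nM in this assay. On that basis, a move toward a lower number, meaning a stronger inhibitor, is expected, although compound 3 may also reach the assay limit. The expected change is an at least 3.1-fold lower number from compound 2 to compound 3 (0.49 log units; beyond the scatter), and its size is uncertain.

For compound 3, the estimated value is 40000 nM, with an expected range of 8000 nM to 125000 nM.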

Compound 3, half-maximal inhibitory concentration: 5000 nM
Compound 3: middle estimate off by 8.0-fold (0.90 log units), on the high side; measured number outside the range, below it.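

In this assay, among the compounds shown here, turning phenyl into 3-methoxyphenyl gives an at least 25-fold lower number from compound 2 to compound 3 (1.39 log units; beyond the scatter), which is the first reading of this change on its own and shows that this place on the six-membered aromatic ring strongly affects the number. Compound 2 stands at a limit of the assay and not at a number, so the step gives only a minimum size: the limit of > 125000 nM in this assay, at which 1 of the 3 values shown sits. The other methoxy in place of hydrogen, the one on the shared core, gives a 2.0-fold lower number from compound 1 to compound 3 (0.30 log units; within the scatter), so with 3-methoxyphenyl present, that change shows no effect that can be told from the scatter.

The compounds shown leave open whether the step belongs to methoxy in particular or would also come with a hydroxyl, a fluorine, an ethoxy or an amine at this same place on the ring. They also leave open how far the acetamide on the core contributes, a question that a free amine or a longer acyl chain there would address.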